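Hydroxamate series on the shared core: the shortened linker

A few compounds are considered here, and "the series" means these few. Any claim that something is new, unique, unknown or untested is made for them only; others in the source may bear on it.

Three members of this series have been measured for cytotoxicity. Compound 1 `O=C(/C=C/c1ccc(CN2C(=O)/C(=C3\Nc4ccccc4\C3=N/O)c3cccc(Cl)c32)cc1)NO` carries a 2-(hydroxycarbamoyl)ethenyl group on the benzyl ring; in a functional assay on PC-3 cells (Homo sapiens) for cytotoxicity, read by colorimetric assay (on this read-out higher numbers stand for weaker inhibition and lower numbers for stronger inhibition), compound 1 gives 90 nM. Compound 2 `O=C(NO)c1ccc(CN2C(=O)/C(=C3\Nc4ccccc4\C3=N/O)c3cccc(Cl)c32)cc1` differs from it in one place, (hydroxycarbamoyl in place of 2-(hydroxycarbamoyl)ethenyl on an aromatic carbon), and in this assay compound 2 gives 60 nM. The step is a 1.5-fold lower number from compound 1 to compound 2 (0.18 log units; within the scatter), so the two numbers are not separated by this assay.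

Compound 3 `O=C(/C=C/c1ccc(CN2C(=O)/C(=C3\Nc4ccccc4\C3=N/O)c3cc(Br)ccc32)cc1)NO` keeps the longer linker of compound 1 on a differently substituted core; the difference between the two cores is not broken down here. In this assay compound 3 gives 90 nM, level with compound 1 and not separated from compound 2 either.

Compound 4 `O=C(NO)c1ccc(CN2C(=O)/C(=C3\Nc4ccccc4\C3=N/O)c3cc(Br)ccc32)cc1`, not yet measured, stands to compound 3 as compound 2 stands to compound 1: hydroxycarbamoyl in place of 2-(hydroxycarbamoyl)ethenyl on an aromatic carbon. The place of the change is described in the same words for both pairs, so this is the same change made on the other core. Among the compounds with values here, since the single measured instance of it, from compound 1 to compound 2, lay within the scatter, the expected step from compound 3 to compound 4 is likewise small, a 1.4-fold lower number from compound 3 to compound 4 (0.14 log units; within the scatter), and rests on that one pair only. Compound 4 is therefore expected to give about 65 nM in this assay, within a range of 30 nM to 140 nM.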

Compound 4, half-maximal inhibitory concentration: 50 nM
Compound 4: middle estimate off by 1.3-fold (0.11 log units), on the high side; the range from low to high includes it.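

In this assay, hydroxycarbamoyl in place of 2-(hydroxycarbamoyl)ethenyl on the core of compound 3 gives a 1.8-fold lower number from compound 3 to compound 4 (0.26 log units; within the scatter), so this assay does not separate the two compounds. Set beside the earlier pair, the change reads alike on the two cores, with no difference between them that this assay can resolve: the same change on two cores in this assay, a 1.5-fold lower number (0.18 log units; within the scatter) from compound 1 to compound 2 and a 1.8-fold lower number (0.26 log units; within the scatter) from compound 3 to compound 4, 1.2-fold (0.08 log units) apart, within the scatter of two such steps Two pairs, each within the scatter, show this agreement and no more: they do not establish that the shorter linker alters the read-out on either core, and they say nothing about any third core.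

On these data alone, all four compounds end in a hydroxycarbamoyl group, so what a carboxylic acid or a plain primary amide at that end of the chain would do to the number in this assay stays open. Also open is how a saturated chain such as 2-(hydroxycarbamoyl)ethyl, or a longer chain between the aromatic ring and the hydroxycarbamoyl group, would compare with the two linkers shown on either core.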